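A Bromophenyl Group in Place of Propyl on the Imidazole Nitrogen

This account rests on a few compounds, and the source may have more. Where it says the series, first, only, none or still open, it means among the compounds named here.

Compound 1 `CCCn1ccnc1-c1cc(OC)c(OC)c(OC)c1` is tested in a functional assay on HT-29 cells (Homo sapiens) for antiproliferative activity, read by MTT assay, with a stated time of 72 h; a lower number here means a stronger inhibitor, a higher number a weaker inhibitor. In this assay compound 1 gives only a limit, > 100000 nM, and no measured number. Among the three values shown, compound 1 sits at the limit (the limit of > 100000 nM in this assay, at which 1 of the 3 values shown sits), so it stands apart from the two measured compounds. Compound 2 `COc1cc(-c2nccn2-c2ccc3sccc3c2)cc(OC)c1OC` gives 1500 nM in this assay, and compound 3 `COc1cc(-c2nccn2-c2ccc3cc[nH]c3c2)cc(OC)c1OC` gives 3600 nM. Both carry a larger group on the same ring nitrogen that holds the propyl chain in compound 1.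

Compound 4 `COc1cc(-c2nccn2-c2ccc(Br)cc2)cc(OC)c1OC` is not yet measured. It differs from compound 1 in one place: 4-bromophenyl in place of propyl on an aromatic nitrogen

Since compound 1 sits at a limit, the size of the step cannot be taken from the shown numbers, yet the values of compound 2 and compound 3 suggest that a ring group on this nitrogen goes with a measured value. The step expected from compound 1 to compound 4 is therefore a large gain in potency, an at least 33-fold lower number from compound 1 to compound 4 (1.52 log units; beyond the scatter). Compound 4 is expected to give about 3000 nM in this assay, within a range from 800 nM to 15000 nM.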

Compound 4, half-maximal inhibitory concentration: 7700 nM
Compound 4: middle estimate off by 2.6-fold (0.41 log units), on the low side, within the range that was stated.
By their numbers in this assay, from the lowest: compound 2; then compound 3; then compound 4. At a limit, above all of these: compound 1.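

In this assay, among the compounds shown here, 4-bromophenyl in place of propyl on this aromatic nitrogen gives an at least 12-fold lower number from compound 1 to compound 4 (1.11 log units; beyond the scatter), the first step at this position that can be read at all. Compound 1 gives a limit and not a number, so this step fixes only the smallest possible size of the change, and its true size stays unknown: the limit of > 100000 nM in this assay, at which 1 of the 4 values shown sits.

The result does add that a single six-membered aromatic ring carrying bromine on this nitrogen is enough to bring a measured number in place of a limit.

The compounds shown leave open what the bromine itself contributes, which a plain phenyl group on this nitrogen would show. They also leave open whether a ring is needed here at all, which a longer chain such as hexyl would test.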